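The source may hold more compounds than are shown below. What is called first, only, known or untested is meant among the compounds shown, and "the series" means these compounds.

In an assay on HepG2 cells for activation of nuclear factor erythroid 2-related factor 2 (Homo sapiens), read by a luciferase reporter, with a stated time of 5 h (a lower number here means that less compound is needed, a higher number that more compound is needed for the effect), compound 1 `Fc1ccc(/C=C/c2ccccc2F)cc1` gives 3600 nM. Compound 2 `Cc1ccc(/C=C/c2ccc(F)cc2F)cc1` gives 2000 nM in this assay. The gap between these two numbers lies within the usual scatter of such measurements, so compound 2 stands level with compound 1 rather than apart from it. Compound 3 `Fc1ccc(/C=C/c2ccc(F)cc2F)cc1` differs from compound 2 by fluoro in place of methyl on an aromatic carbon. For the measured compounds named here, no measured pair shows this exact change, so only a small step in this assay is expected, in either direction, probably none beyond the scatter. Compound 3 is therefore expected to give about 2800 nM, between 1200 nM and 6500 nM. That expectation corresponds to a 1.4-fold higher number from compound 2 to compound 3 (0.15 log units; within the scatter) in this assay.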

Compound 3, half-maximal effective concentration: 900 nM
For compound 3 the middle estimate is 3.1-fold (0.49 log units) above the measured one, outside the stated range (below it).
By their numbers in this assay, from the lowest: compound 3; then compounds 2 and 1 (each within the scatter of the next).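

In this assay, fluoro in place of methyl on an aromatic carbon, para to a large group, gives a 2.2-fold lower number from compound 2 to compound 3 (0.35 log units; beyond the scatter). For the compounds shown here, this is the first step at this position that stands clear of the scatter, so the group here does matter. Fluoro in place of hydrogen on an aromatic carbon points the same way, with a 4.0-fold lower number from compound 1 to compound 3 (0.60 log units; beyond the scatter). Nothing available explains why these changes lower the number. From the compounds shown here alone, it remains open whether chloro, methoxy or an amine at this position would lower the number further or raise it again.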